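A few compounds are considered here, and "the series" means these few. Any claim that something is new, unique, unknown or untested is made for them only; others in the source may bear on it.

Working notes on the series. The compounds share a common core and differ in the group carried on the sulfonamide nitrogen. Compound 1 `Cc1cccc(NS(=O)(=O)c2ccc(N3CCNC3=O)cc2)c1` is the reference followed here; in a functional assay on HT-29 cells (Homo sapiens) for antiproliferative activity, read by sulforhodamine B assay, with a stated time of 48 h (on this read-out lower numbers stand for stronger inhibition and higher numbers for weaker inhibition), compound 1 gives 110 nM. Two further members have been measured. Compound 2 `O=C1NCCN1c1ccc(S(=O)(=O)Nc2ccc3c(c2)CCC3)cc1` gives 190 nM in this assay, and compound 3 `COc1cc(NS(=O)(=O)c2ccc(N3CCNC3=O)cc2)cc(OC)c1` gives 78 nM. Compound 1 therefore stands as the second highest of the three numbers, but both its neighbours lie within the usual scatter of repeated measurements, so no order among the three can be claimed.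

Compound 4 `COc1ccccc1NS(=O)(=O)c1ccc(N2CCNC2=O)cc1` has not yet been measured in this assay. Its difference from compound 1 is 2-methoxyphenyl in place of 3-methylphenyl on a sulfonamide nitrogen. Within the data shown here, no pair of measured compounds differing in one place exists in the set, so this change has no direct precedent. Since the three measured variations on the sulfonamide nitrogen all fall within the scatter of one another, the expectation is that the step of a 1.4-fold higher number from compound 1 to compound 4 (0.13 log units; within the scatter) also stays within the scatter, with no clear direction. Compound 4 is accordingly expected to give about 150 nM in this assay, with a range from 60 nM to 400 nM.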

Compound 4, half-maximal inhibitory concentration: 550 nM
Compound 4: middle estimate off by 3.7-fold (0.56 log units), on the low side; measured number outside the range, above it.
By their numbers in this assay, from the lowest: compounds 3, 1 and 2 (each within the scatter of the next, the first and the last beyond it); then compound 4.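

In this assay, among these compounds, the group on the sulfonamide nitrogen proves able to shift the number well beyond the scatter: a 5.0-fold higher number from compound 1 to compound 4 (0.70 log units; beyond the scatter) is the first step read between two compounds differing in one place. The position is therefore not indifferent to which substituted phenyl it carries, since 2-methoxyphenyl brings in an oxygen and a hydrogen-bond acceptor on the same six-membered aromatic ring as 3-methylphenyl and goes with weaker inhibition. Nothing at hand bears on what lies behind this step.

Still open, on these data alone, is whether the step belongs to the methoxy group as such or to its place on the ring. Also open, as far as these compounds go, is how a pyridine ring, or a phenyl ring carrying an amine or a carboxylic acid, would behave on this nitrogen.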